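The source may hold more compounds than are shown below. What is called first, only, known or untested is meant among the compounds shown, and "the series" means these compounds.

Compound 1 `COc1ccc(/C=C\c2cc(OC)c(OC)c(OC)c2)cc1OCc1ccc(CN2C[C@H](O)C[C@@H]2C(=O)O)cc1` is the starting point of this account. In an ADME assay on NCM460 cells (Homo sapiens) for cytotoxicity, read by CCK-8 assay, with a stated time of 48 h (a higher number here means a weaker inhibitor, a lower number a stronger inhibitor), compound 1 gives > 50000 nM, which is a limit of the assay rather than a number. Two close relatives on the same core have been measured. Compound 2 `COc1ccc(/C=C\c2cc(OC)c(OC)c(OC)c2)cc1OCc1ccc(CN2CC[C@H](O)C2)cc1` gives 51000 nM in this assay. Compound 3 `COc1ccc(/C=C\c2cc(OC)c(OC)c(OC)c2)cc1OCc1ccc(CN2CC[C@@H](C(=O)O)C2)cc1` gives > 50000 nM in this assay, again a limit and not a number. Hence the step that the limit leaves unreadable from compound 1 to compound 2 and the step that the two limits leave unreadable from compound 1 to compound 3 cannot be sized, and the same holds for a step that the limit leaves unreadable from compound 2 to compound 3; what ties the three values together is the limit of > 50000 nM in this assay, at which 2 of the 3 values shown sit, so compound 1 stands together with its relatives at the edge of what this assay reads.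

Compound 4 `COc1ccc(/C=C\c2cc(OC)c(OC)c(OC)c2)cc1OCc1ccc(CN[C@H](C(=O)O)[C@@H](C)O)cc1` has not yet been measured. It differs from compound 1 in one place: (1-carboxy-2-hydroxypropyl)amino in place of 2-carboxy-4-hydroxypyrrolidin-1-yl on a saturated chain carbon bound to an aromatic carbon. Going by the values given here, no measured step exchanges this particular pair of groups, and the steps that swap groups at the same carbon are all unreadable because of the limit of > 50000 nM in this assay, at which 2 of the 3 values shown sit. The measured compounds therefore leave no evidence for a readable step in either direction. The expected step is a number no higher from compound 1 to compound 4 (the limit leaves the size open), none beyond the scatter. Compound 4 is expected to give about 50000 nM in this assay, between 25000 nM and 100000 nM, with a fair chance that only a limit is reported.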

Compound 4, half-maximal inhibitory concentration: > 50000 nM
Compound 4: only a limit was reported (the forecaster's own chance of this, stated with the estimate: 60%); the middle value lies on the limit itself.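

In this assay compound 4 gives > 50000 nM, a limit and not a number. No step from compound 1, compound 2 or compound 3 to compound 4 can be read, because the values meet at one edge: the limit of > 50000 nM in this assay, at which 3 of the 4 values shown sit.

The compounds shown leave open how the groups exchanged at this saturated chain carbon compare, since the values of compound 1, compound 3 and compound 4 are limits.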